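Thiophene-to-methylpyrazole swap on the biaryl arm

The source may hold more compounds than are shown below. What is called first, only, known or untested is meant among the compounds shown, and "the series" means these compounds.

Measured so far:
- compound 1 `O=C(Nc1c(F)cc(F)cc1F)N(Cc1ccc(-c2cccs2)cc1)C1CCCCCC1`: > 1 mg/kg
- compound 2 `COc1cccc(CN(Cc2cccc(-c3cc[nH]n3)c2)C(=O)Nc2c(SC)cc(C)nc2SC)c1`: > 0.1 mg/kg
- compound 3 `Cc1cc(C)c(NC(=O)N(Cc2ccc(-c3cccs3)cc2)C2CCCCCC2)c(C)c1`: 0.28 mg/kg

For the measured compounds named here, in a functional assay on a cell-free system (plasma) with sterol O-acyltransferase, Soat (Rattus norvegicus) as the target (a higher number here means that more compound is needed for the effect, a lower number that less compound is needed), compound 3 gives 0.28 mg/kg and is the only compound of the three with a number rather than a limit. For compound 1 the result in this assay is a limit, > 1 mg/kg (the limit of > 1 mg/kg in this assay, at which 1 of the 3 values shown sits). For compound 2 the result is likewise a limit, > 0.1 mg/kg (the limit of > 0.1 mg/kg in this assay, at which 1 of the 3 values shown sits). Going by the values given here, compound 2 differs from compound 3 in more than one place, so its value shows no step that can be read against the present change.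

Among the compounds with values here, the one step with both ends on the same core is an at least 3.5-fold lower number from compound 1 to compound 3 (0.55 log units; beyond the scatter), and it concerns the aryl on the amide-type nitrogen, not the arm that changes here.

Compound 4 `Cc1cc(C)c(NC(=O)N(Cc2ccc(-c3ccnn3C)cc2)C2CCCCCC2)c(C)c1` carries 1-methyl-1H-pyrazol-5-yl in place of thiophen-2-yl on an aromatic carbon. No measured pair in the series varies this arm alone, so the size and direction of the step in this assay cannot be drawn from shown data. The expectation is therefore set near compound 3, with a wide range allowing a loss: for compound 4 the estimate in this assay is 0.45 mg/kg, between 0.15 mg/kg and 1.5 mg/kg, which would mean a step of a 1.6-fold higher number from compound 3 to compound 4 (0.21 log units; within the scatter).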

Compound 4, dose for half-maximal effect: < 1 mg/kg
Compound 4 gave a limit, no number; the forecaster's own chance of this, stated with the estimate: 30%; the middle value lies beyond the limit too.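

In this assay, for the compounds shown here, compound 4 gives < 1 mg/kg, which is a limit and not a number, so no step from compound 3 to compound 4 can be read. The compounds shown leave open how far, and in which direction, 1-methyl-1H-pyrazol-5-yl in place of thiophen-2-yl moves the result in this assay.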